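This account rests on a few compounds, and the source may have more. Where it says the series, first, only, none or still open, it means among the compounds named here.

Going by the values given here, compound 2 `CCCn1c(=O)c2nc(C(C)(C)C)[nH]c2n(CCC)c1=O` gives the only number so far in an assay on cell membranes for binding affinity to adenosine receptor A1 (Cavia porcellus), read by radioligand binding (on this read-out lower numbers stand for stronger inhibition and higher numbers for weaker inhibition), namely 31 nM. Compound 1 `CCCn1c(=O)c2nc(-c3nn[nH]n3)[nH]c2n(CCC)c1=O` reaches only a limit in this assay, > 10000 nM, which is a limit and not a number (the limit of > 10000 nM in this assay, at which 1 of the 2 values shown sits). Among the compounds with values here, the single measured step, an at least 320-fold lower number from compound 1 to compound 2 (2.50 log units; beyond the scatter), replaced 2H-tetrazol-5-yl by tert-butyl. Compound 3 `CCCn1c(=O)c2nc(C(C)(O)CC)[nH]c2n(CCC)c1=O` carries 1-hydroxy-1-methylpropyl in place of tert-butyl on an aromatic carbon. That measured step bears only loosely on exchanging one small alkyl group for a similar one carrying a hydroxyl, so a modest step toward a higher number is expected. Compound 3 is estimated at 100 nM, between 30 nM and 400 nM. This expectation means a 3.2-fold higher number from compound 2 to compound 3 (0.51 log units; beyond the scatter).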

Compound 3, inhibition constant: 240 nM
Compound 3: the middle estimate sits 2.4-fold (0.38 log units) below what was measured, within the range that was stated.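

In this assay, a group carrying a hydroxyl at this position between two ring nitrogen atoms still gives a measurable number, but the change costs something, with a 7.7-fold higher number from compound 2 to compound 3 (0.89 log units; beyond the scatter) in this series. Even so, 1-hydroxy-1-methylpropyl stands far closer to tert-butyl than 2H-tetrazol-5-yl does, with an at least 41-fold lower number from compound 1 to compound 3 (1.61 log units; beyond the scatter) for that exchange. This last step starts from a limit and not a number: the limit of > 10000 nM in this assay, at which 1 of the 3 values shown sits.

The compounds shown leave open how an amine or a carboxylic acid would read at this position. As far as these compounds go, whether a hydroxyl on a longer chain would give a lower or a higher number also stays open.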